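The compounds below may be only part of what the source reports. "The series", "measured", "known", "first", "only" and "open" are said of these compounds alone.

Compound 3 `NCCC(=O)Nc1nc2ccc(NC(=O)c3c(Cl)cccc3Cl)cc2s1` stands highest of the three numbers in a functional assay on WI-38 VA13 cells (Homo sapiens) for cytotoxicity; on this read-out higher numbers stand for an effect only at larger amounts of compound and lower numbers for an effect already at smaller amounts: compound 3 gives 5.3 ug/mL, while compound 1 `Cc1nc(C)c(C(=O)Nc2ccc3nc(NC(=O)C4CCCCC4)sc3c2)s1` gives 0.39 ug/mL and compound 2 `Cc1cccc(C)c1NC(=O)Nc1ccc2nc(NC(=O)C3CCCCC3)sc2c1` gives 0.56 ug/mL. Among the compounds with values here, the only step measured within one change, a 1.4-fold higher number from compound 1 to compound 2 (0.16 log units; within the scatter), lies at a different place on the shared core and is within the scatter, so it gives no direct guide to the change at hand. Compound 4 `CCCCNC(=O)Nc1nc2ccc(NC(=O)c3c(Cl)cccc3Cl)cc2s1` carries butylamino in place of 2-aminoethyl on a carbonyl carbon. Within the data shown here, no measured pair shows this exchange, so the size and direction of the step rest on no data; with nothing pointing either way, no step beyond the scatter is assumed. Compound 4 is therefore expected at about 4.5 ug/mL in this assay, with a range from 1.2 ug/mL to 17 ug/mL, which corresponds to an estimated 1.2-fold lower number from compound 3 to compound 4 (0.07 log units; within the scatter).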

Compound 4, half-maximal effective concentration: 0.028 ug/mL
Compound 4: the middle estimate sits 160-fold (2.21 log units) above what was measured; the whole stated range lies above it.
By their numbers in this assay, from the lowest: compound 4; then compounds 1 and 2 (each within the scatter of the next); then compound 3.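

At the carbonyl carbon whose other neighbour is an amide-type nitrogen, butylamino in place of 2-aminoethyl gives a 190-fold lower number from compound 3 to compound 4 (2.28 log units; beyond the scatter) in this assay. This is the first step shown at this place and, unlike the earlier step at another place, it lies beyond the scatter, so this position can move the number by a large amount. Nothing measured here bears on the reason for this step.

The exchange removes the terminal amine of 2-aminoethyl and also alters the chain and its link to the carbonyl, and the compounds shown do not separate these changes. Going by these compounds, it remains open whether pentyl on the same carbonyl carbon, or a longer chain such as hexylamino, would follow butylamino.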